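A carbonyl replaced by a hydroxy group in compound 2

The source may report more compounds than this note shows. Statements on the series, on what has been measured and on what is new or still open speak of the compounds shown alone.

Compound 1 `CCN(CC)CCNC(=O)c1ccc(C(CC)(CC)c2ccc(OCC(O)C(C)(C)C)c(C)c2)n1CC` reads 490 nM
Compound 2 `CC[C@@H](C)[C@H](NC(=O)c1ccc(C(CC)(CC)c2ccc(OCC(=O)C(C)(C)C)c(C)c2)n1CC)C(=O)O` reads 247 nM

Both values come from a functional assay on HepG2 cells (Homo sapiens), read by MTT assay, with a stated time of 48 h (on this read-out higher numbers stand for weaker inhibition and lower numbers for stronger inhibition), and lie within the usual scatter of each other, so compound 2 stands level with compound 1 on these numbers. Compound 3 `CC[C@@H](C)[C@H](NC(=O)c1ccc(C(CC)(CC)c2ccc(OCC(O)C(C)(C)C)c(C)c2)n1CC)C(=O)O` keeps all of compound 2 except one group. The change 1-hydroxy-2,2-dimethylpropyl in place of (tert-butyl)carbonyl on a saturated chain carbon bound to an oxygen on an aromatic ring puts 1-hydroxy-2,2-dimethylpropyl in place of (tert-butyl)carbonyl on a saturated chain carbon bound to an oxygen on an aromatic ring. Among the measured compounds shown here, compound 1 already carries the 2-hydroxy-3,3-dimethylbutoxy group, but it also differs from compound 2 at the amide, so no measured pair isolates this change. Since compound 1 with that group reads 490 nM in this assay, no step beyond the scatter is expected, with at most a slight drift toward higher numbers. The estimated size is a 1.2-fold higher number from compound 2 to compound 3 (0.08 log units; within the scatter) in this comparison. For compound 3 the expected value is 300 nM with 130 nM to 700 nM as the estimated range.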

Compound 3, half-maximal inhibitory concentration: 127 nM
Beside the measured number, compound 3's estimate is 2.4-fold (0.37 log units) above it, outside the stated range (below it).
By their numbers in this assay, from the lowest: compounds 3, 2 and 1 (each within the scatter of the next, the first and the last beyond it).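

In this assay, 1-hydroxy-2,2-dimethylpropyl in place of (tert-butyl)carbonyl on a saturated chain carbon bound to an oxygen on an aromatic ring gives a 1.9-fold lower number from compound 2 to compound 3 (0.29 log units; within the scatter), so this position accepts the hydroxy group as well as the carbonyl on these numbers. Among the compounds shown here, with the 2-hydroxy-3,3-dimethylbutoxy group now held constant, 1-carboxy-2-methylbutyl in place of 2-(diethylamino)ethyl on an amide-type nitrogen gives a 3.9-fold lower number from compound 1 to compound 3 (0.59 log units; beyond the scatter), the first single-place step here that lies beyond the scatter. Nothing available explains the size of either step.

Still open, going by these compounds, is whether an amine or a methoxy group at the same chain carbon would read level with the hydroxy group. Also open, on these data alone, is how a methyl ester in place of the carboxylic acid would read at the amide-type nitrogen.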